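From 3-iodophenyl to 4-fluorophenyl on a shared core

The compounds below may be only part of what the source reports. "The series", "measured", "known", "first", "only" and "open" are said of these compounds alone.

Measured in a functional assay on HT-29 cells (Homo sapiens) for antiproliferative activity, read by sulforhodamine B assay, with a stated time of 48 h; on this read-out lower numbers stand for stronger inhibition and higher numbers for weaker inhibition
- compound 1 `COc1ccccc1OS(=O)(=O)c1ccc(N2CCN(C)C2=O)cc1` gives 26000 nM
- compound 2 `Cc1cccc(OS(=O)(=O)c2ccc(N3CCN(C)C3=O)cc2)c1` gives 4300 nM
- compound 3 `CN1CCN(c2ccc(S(=O)(=O)Oc3cccc(I)c3)cc2)C1=O` gives 590 nM

Compound 3 holds the lowest number of the three, and the gaps to the other two lie beyond the scatter. Compound 4 `CN1CCN(c2ccc(S(=O)(=O)Oc3ccc(F)cc3)cc2)C1=O` differs from compound 3 in one place only, and that change reads 4-fluorophenyl in place of 3-iodophenyl on an oxygen with the shared core untouched.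

Among the measured compounds shown here, no measured compound carries 4-fluorophenyl, so no step speaks to it directly. For the measured compounds named here, the available guide is that compound 3 is the only measured compound with 3-iodophenyl, and both steps that reach it went lower: a 7.3-fold lower number from compound 2 to compound 3 (0.86 log units; beyond the scatter) was modest and a 44-fold lower number from compound 1 to compound 3 (1.64 log units; beyond the scatter) was large. Compound 4 gives up that group, so the gain may be lost, although the data cannot show how far.

A rise is expected in this assay with an estimated 8.5-fold higher number from compound 3 to compound 4 (0.93 log units; beyond the scatter) of roughly modest size. For compound 4 the estimated value is 5000 nM within an expected range of 1500 nM to 20000 nM for this measurement.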

Compound 4, half-maximal inhibitory concentration: > 100000 nM
Compound 4 was reported as a limit; the forecaster's own chance of this, stated with the estimate: 5%; middle value at least 20-fold (1.30 log units) from the limit.
By their numbers in this assay, from the lowest: compound 3; then compound 2; then compound 1. At a limit, above all of these: compound 4.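

In this assay compound 4 is reported only as a limit: the limit of > 100000 nM in this assay, at which 1 of the 4 values shown sits. Replacing the group on this oxygen gives an at least 160-fold higher number from compound 3 to compound 4 (2.22 log units; beyond the scatter), alongside an at least 23-fold higher number from compound 2 to compound 4 (1.36 log units; beyond the scatter) and an at least 3.8-fold higher number from compound 1 to compound 4 (0.58 log units; beyond the scatter), so 4-fluorophenyl ends up past even the 2-methoxyphenyl of compound 1, and this position spans a far wider range than the first three compounds revealed. The change also keeps the heavy-atom count, the ring and the hydrogen-bond counts given for the two groups, so none of these counted features separates 3-iodophenyl from 4-fluorophenyl.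

The step changes the halogen and its place on the ring together, and the compounds shown do not tell these two apart. As far as these compounds go, a 3-fluorophenyl or a 4-iodophenyl group on the same oxygen would separate them, and how far compound 4 lies beyond its limit stays unknown.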